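A few compounds are considered here, and "the series" means these few. Any claim that something is new, unique, unknown or untested is made for them only; others in the source may bear on it.

Measured so far:
compound 1 `CC1=NC(C)=C([N+](=O)[O-])C(c2cccnc2)/C1=C(\O)OC1CCCC1` — 3280 nM
compound 2 `CC1=NC(C)=C([N+](=O)[O-])C(c2ccncc2)/C1=C(\O)OC(C)C` — 8050 nM

Going by the values given here, only two compounds have a number in a functional assay (cardiac atrium) for agonist activity, with Cavia porcellus as the target (on this read-out lower numbers stand for an effect already at smaller amounts and higher numbers for an effect only at larger amounts of compound), and compound 2 stands at the higher of the two, needing more compound than compound 1 before the tissue responds; the gap between them is larger than repeated measurements usually scatter. Compound 1 and compound 2 differ from each other in more than one place, so the two values alone do not tell which part of the structure carries the gap.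

The next step leads from compound 2 to compound 3 `CC1=NC(C)=C([N+](=O)[O-])C(c2ccncc2)/C1=C(\O)OC1CCCC1`, a single change: cyclopentyl in place of isopropyl on an oxygen on an unsaturated carbon. Among the compounds with values here, compound 1 also carries the cyclopentyl group on that oxygen, yet it differs from compound 3 in a second place as well, so no step of known size can be borrowed from it. With that in mind, only a modest shift toward a lower number is expected in this assay, and a result within the usual scatter would not be surprising.

For compound 3 the estimate in this assay is 5000 nM, within a range of 2000 nM to 12000 nM, which means an expected step of a 1.6-fold lower number from compound 2 to compound 3 (0.21 log units; within the scatter).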

Compound 3, half-maximal effective concentration: 4250 nM
For compound 3 the middle estimate is 1.2-fold (0.07 log units) above the measured one; the range from low to high includes it.
By their numbers in this assay, from the lowest: compounds 1, 3 and 2 (each within the scatter of the next, the first and the last beyond it).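

Going by these compounds alone, compound 3 is the first compound here that differs from each earlier compound in one place only, so the two changes can be read apart in this assay. Cyclopentyl in place of isopropyl on an oxygen on an unsaturated carbon gives a 1.9-fold lower number from compound 2 to compound 3 (0.28 log units; within the scatter), and pyridin-4-yl in place of pyridin-3-yl on a saturated ring carbon gives a 1.3-fold higher number from compound 1 to compound 3 (0.11 log units; within the scatter). Since both steps stay within the usual scatter, neither change alone accounts for the gap beyond the scatter between the two earlier compounds, and nothing measured here offers an explanation for the size of either step.

On these data alone, each change has been seen only once, with a single pair of groups on one background, so it remains open whether the same swap would give a similar step elsewhere on the shared core. As far as these compounds go, it also remains open whether a different group on that oxygen, such as a longer chain or a chain carrying an amine, would give a step beyond the scatter, or whether pyridin-2-yl on the saturated ring carbon would do so.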